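A few compounds are considered here, and "the series" means these few. Any claim that something is new, unique, unknown or untested is made for them only; others in the source may bear on it.

Measured compounds in a functional assay on HCT-15 cells (Homo sapiens) for inhibition; a lower number here means a stronger inhibitor, a higher number a weaker inhibitor:
compound 1, `Oc1cccc(-c2cc(-c3ccccc3F)cc(-c3ccccc3O)n2)c1`: 8470 nM
compound 2, `Oc1cccc(-c2cc(-c3ccccc3F)cc(-c3cccc(O)c3)n2)c1`: 5300 nM

For the measured compounds named here, compound 2 is the reference point; the only other number, from compound 1, sits within the scatter of it, the single measured step being a 1.6-fold lower number from compound 1 to compound 2 (0.20 log units; within the scatter). Going by the values given here, that step concerns a hydroxyphenyl group and its position on the shared core; it says nothing about the group opposite the ring nitrogen, and no other step has been measured.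

Compound 3, `Oc1cccc(-c2cc(-c3cccc(C(F)(F)F)c3)cc(-c3cccc(O)c3)n2)c1`, differs from compound 2 by 3-(trifluoromethyl)phenyl in place of 2-fluorophenyl on an aromatic carbon. Among the compounds with values here, no measured step touches this position, so there is no basis in the data for a shift beyond the scatter in either direction; the two numbers in this assay so far lie close together. Compound 3 is therefore expected to give about 5000 nM in this assay, with a range of 1500 nM to 16000 nM, which corresponds to an expected step of a 1.1-fold lower number from compound 2 to compound 3 (0.03 log units; within the scatter).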

Compound 3, half-maximal inhibitory concentration: 13600 nM
Compound 3: middle estimate off by 2.7-fold (0.43 log units), on the low side; the measured number falls inside the stated range.
By their numbers in this assay, from the lowest: compounds 2, 1 and 3 (each within the scatter of the next, the first and the last beyond it).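

With both 3-hydroxyphenyl groups held fixed, 3-(trifluoromethyl)phenyl in place of 2-fluorophenyl opposite the ring nitrogen gives in this assay a 2.6-fold higher number from compound 2 to compound 3 (0.41 log units; beyond the scatter) and thus a shift beyond the scatter, which the earlier hydroxyphenyl step did not produce. This position therefore responds to a change of its aryl group, and of the two groups compared here, 2-fluorophenyl goes with the lower number. No measurement available here bears on the origin of this shift.

The step changes both the substituent and where it sits on the phenyl ring, and the two contributions cannot be separated. Also open, on these data alone, is how an unsubstituted phenyl, or a phenyl carrying an amine or a carboxylic acid, would read at this position.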